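The compounds below may be only part of what the source reports. "The series", "measured", "known", "first", "only" and "open" are said of these compounds alone.

The study includes two measured compounds and one that is still to be tested. Compound 1 `COc1cc(/C=N/NC(=O)Nc2cccc3ccccc23)cc(OC)c1OC` and compound 2 `COc1cc(/C=N/NC(=O)Nc2cccc3ccccc23)ccc1O` share the same core and differ on the substituted ring. In a functional assay on the whole organism (strain Swiss albino) with Mus musculus as the target, with a stated time of 0.5 h (on this read-out lower numbers stand for an effect already at smaller amounts and higher numbers for an effect only at larger amounts of compound), compound 1 gives 100 mg/kg and compound 2 gives 300 mg/kg, so compound 2 carries the highest number of the two, and its gap to compound 1 lies beyond the usual scatter of repeated measurements.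

Compound 3 `COc1ccc(/C=N/NC(=O)Nc2cccc3ccccc23)cc1OC` has not yet been tested. It arises from compound 2 by methyl in place of hydrogen on an oxygen on an aromatic ring, a change that brings compound 3 closer to the substitution pattern of compound 1. Within the data shown here, no step between measured compounds is known that matches this change. The direction of the expected step from compound 2 to compound 3 is estimated as a 2.0-fold lower number from compound 2 to compound 3 (0.30 log units; within the scatter), towards a lower number, because compound 1 gives 100 mg/kg. In this assay compound 3 is therefore expected to give about 150 mg/kg, within a range from 60 mg/kg to 300 mg/kg.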

Compound 3, minimum effective dose: 100 mg/kg
Estimate against measurement, compound 3: 1.5-fold (0.18 log units) above; measured number inside the range.
By their numbers in this assay, from the lowest: compounds 1 and 3 (each within the scatter of the next); then compound 2.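

In this assay, among these compounds, the change from hydroxy to methoxy on the aromatic ring gives the first readable step at this oxygen, a 3.0-fold lower number from compound 2 to compound 3 (0.48 log units; beyond the scatter) and this places the effect of methyl in place of hydrogen beyond the scatter. Hydrogen in place of methoxy on an aromatic carbon behaves differently, with no change at the digits printed from compound 1 to compound 3 (within the scatter) and so, within this set, the additional methoxy of compound 1 brings no readable gain over compound 3. The data given offer no explanation for either step.

On these data alone, it remains open whether this oxygen would keep the same read-out with an ethyl group or a longer chain in place of methyl. As far as these compounds go, it is equally open how an amine or a carboxylic acid in place of the hydroxy of compound 2 would read.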